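This account rests on a few compounds, and the source may have more. Where it says the series, first, only, none or still open, it means among the compounds named here.

Three compounds have numbers in a functional assay on DU-145 cells (Homo sapiens) for cytotoxicity, read by trypan blue exclusion, with a stated time of 96 h; a lower number here means a stronger inhibitor, a higher number a weaker inhibitor. In this assay compound 1 `COc1ccc(NS(=O)(=O)/C=C/c2c(F)c(F)c(F)c(F)c2F)cc1F` gives 10000 nM, compound 2 `O=S(=O)(/C=C/c1ccccc1)Nc1ccc(Cl)cc1` gives 20000 nM, and compound 3 `O=S(=O)(/C=C/c1ccc(Br)cc1)Nc1ccc(F)cc1` gives 10000 nM. Compound 3 stands level with compound 1, and compound 2 lies within the scatter of both, so the three values show no order among them.

Compound 4 `COc1ccc(/C=C/S(=O)(=O)Nc2ccc(F)cc2)cc1` has not yet been measured. It differs from compound 3 in one place, methoxy in place of bromo on an aromatic carbon, para to a large group. Among the measured compounds shown here, no two measured compounds differ in one place only, so the data give no direct measure of this change. The expectation therefore rests on compound 3 at 10000 nM, and no step beyond the scatter is expected in this assay. The estimated step is a 1.3-fold lower number from compound 3 to compound 4 (0.10 log units; within the scatter), which would stay within the scatter. For compound 4 the estimated value is 8000 nM, with an expected range from 2500 nM to 20000 nM.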

Compound 4, half-maximal inhibitory concentration: 10000 nM
Compound 4: middle estimate off by 1.3-fold (0.10 log units), on the low side; the range from low to high includes it.
By their numbers in this assay, from the lowest: compounds 1, 3, 4 and 2 (each within the scatter of the next).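

Among the compounds shown here, the pair of compound 3 and compound 4 gives the first direct reading of a single change in this set: in this assay, methoxy in place of bromo on an aromatic carbon, para to a large group, produces no change at the digits printed from compound 3 to compound 4 (within the scatter) and so leaves the number where it was. At this position, a group with one hydrogen-bond acceptor and a group with none give values that cannot be told apart. Nothing at hand explains this result.

On these data alone, whether an amine or a carboxylic acid at the same position would also stay within the scatter remains open. So does whether a longer chain, such as butoxy, would do so.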